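The source may hold more compounds than are shown below. What is called first, only, known or untested is meant among the compounds shown, and "the series" means these compounds.

Measured compounds:
- Compound 1 `CC(=O)N[C@H]1[C@H](O)[C@@H](O)[C@H](CO)O[C@H]1n1cc(CN2CCN(c3cccc4[nH]c(-c5ccc(C(C)(C)C)cc5)nc34)CC2)nn1`: in a functional assay on cells for antagonist activity at Gonadotropin-releasing hormone receptor (Homo sapiens), read by FLIPR and calcium flux, with a stated time of 15 min (on this read-out lower numbers stand for stronger inhibition and higher numbers for weaker inhibition), compound 1 gives > 10000 nM, a limit of the assay and not a number.
- Compound 2 `CC(C)(C)c1ccc(-c2nc3c(N4CCN(Cc5cn([C@@H]6O[C@H](CO)[C@@H](O)[C@H](O)[C@H]6O)nn5)CC4)cccc3[nH]2)cc1`: in this assay compound 2 gives > 10000 nM, again a limit and not a number.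
- Compound 3 `CC(C)(C)c1ccc(-c2nc3c(N4CCN(Cc5cccc6nccnc56)CC4)cccc3[nH]2)cc1`: in this assay compound 3 gives 631 nM.

Compound 2 stands at the limit of > 10000 nM in this assay, at which 2 of the 3 values shown sit, so among the three values shown its position is known only as lying at that boundary; compound 3 is the one of the three that returns a number. Compound 4 `CC(C)(C)c1ccc(-c2nc3c(N4CCN(Cc5cn(-c6nc7ccccc7[nH]6)nn5)CC4)cccc3[nH]2)cc1` differs from compound 2 in one place: 1H-benzimidazol-2-yl in place of 3,4,5-trihydroxy-6-(hydroxymethyl)oxan-2-yl on an aromatic nitrogen. Within the data shown here, no two measured compounds differ in a single place, so no measured step size is available for comparison. A step toward stronger inhibition, beyond the usual scatter, is expected an at least 5.0-fold lower number from compound 2 to compound 4 (0.69 log units; beyond the scatter), because compound 3 without any sugar gives 631 nM in this assay. Compound 4 is therefore estimated at 2000 nM, with the expected range running from 300 nM to 10000 nM; a limit rather than a number remains a real possibility.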

Compound 4, half-maximal inhibitory concentration: 5010 nM
Compound 4: middle estimate off by 2.5-fold (0.40 log units), on the low side, and the stated range covers the measured number.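

In this assay, among these compounds, 1H-benzimidazol-2-yl in place of 3,4,5-trihydroxy-6-(hydroxymethyl)oxan-2-yl on the aromatic nitrogen gives an at least 1.9-fold lower number from compound 2 to compound 4 (0.30 log units; that floor lies within the scatter), and compound 4 is the first compound here with a group on that nitrogen to return a number. Compound 2 gives a limit of the assay and not a number: the limit of > 10000 nM in this assay, at which 2 of the 4 values shown sit. This position can therefore carry a group of two fused aromatic rings and still give a measurable read-out, although the floor of the step alone does not show a change beyond the scatter.

The step swaps the oxane ring and its hydroxyl groups for the fused aromatic rings in one move, so it does not tell which of these differences matters. A phenyl, a methyl, an amine or a carboxylic acid on the same nitrogen would help to separate them.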